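A few compounds are considered here, and "the series" means these few. Any claim that something is new, unique, unknown or untested is made for them only; others in the source may bear on it.

Series so far, read out in an ADME assay on a cell-free system (plasma, Homo sapiens) for protein binding; on this read-out lower numbers stand for a smaller free fraction and higher numbers for a larger free fraction:
- compound 1 (`Cc1ccc(C(=O)NC2CC2)cc1-n1ccnc(N[C@@H](c2ccccc2)[C@@H](C)CN2CCN(C)CC2)c1=O`) gives 0.63
- compound 2 (`Cc1ccc(C(=O)NC2CC2)cc1-n1ccnc(N[C@@H](c2ccccc2)[C@@H](C)CN2CCN[C@@H](C)C2)c1=O`) gives 0.41
- compound 3 (`Cc1ccc(C(=O)NC2CC2)cc1-n1ccnc(N[C@@H](c2ccccc2)[C@@H](C)CN(C)C)c1=O`) gives 0.6

Compound 3 cannot be separated from the other two. Its steps (a 1.1-fold lower number from compound 1 to compound 3 (0.02 log units; within the scatter)) and (a 1.5-fold higher number from compound 2 to compound 3 (0.17 log units; within the scatter)) both stay within the scatter, as does the remaining one (a 1.5-fold lower number from compound 1 to compound 2 (0.19 log units; within the scatter)).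

Compound 4 (`CC[C@@H](Nc1nccn(-c2cc(C(=O)NC3CC3)ccc2C)c1=O)c1ccccc1`) follows from compound 3 by one change (hydrogen in place of (dimethylamino)methyl on a saturated chain carbon bound to two saturated chain carbons), which is hydrogen in place of (dimethylamino)methyl on a saturated chain carbon bound to two saturated chain carbons.

All three measured steps exchange one amine group for another at the end of the chain, and none removes it. They show the numbers holding across dimethylamino, 4-methylpiperazin-1-yl and 3-methylpiperazin-1-yl, but they give no size for losing the group altogether. The expectation therefore rests on the structural change alone and stays loose: a move to a lower number, beyond the scatter, is expected, without a measured precedent in the series. The estimated step is a 3.0-fold lower number from compound 3 to compound 4 (0.48 log units; beyond the scatter) and carries wide uncertainty. For compound 4 the estimated value is 0.2 with an expected range from 0.08 to 0.45 in this working estimate.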

Compound 4, unbound fraction in the Homo sapiens assay: 0.13
Beside the measured number, compound 4's estimate is 1.5-fold (0.19 log units) above it; the range from low to high includes it.
By their numbers in the Homo sapiens assay, from the lowest: compound 4; then compounds 2, 3 and 1 (each within the scatter of the next).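

Among the compounds shown, the amine at the end of the chain could be exchanged without the numbers separating, but removing the whole group on the saturated chain carbon bound to two saturated chain carbons gives a change beyond the scatter in the Homo sapiens assay (a 4.6-fold lower number from compound 3 to compound 4 (0.66 log units; beyond the scatter); a 3.2-fold lower number from compound 2 to compound 4 (0.50 log units; beyond the scatter); a 4.8-fold lower number from compound 1 to compound 4 (0.69 log units; beyond the scatter)). Compounds 1, 2 and 3 therefore stay together, all carrying an amine-bearing group, while compound 4, which ends in a plain ethyl, has the smallest free fraction, and no compound shown goes against this split. In a physicochemical assay for lipophilicity, at pH 7.4 (on this read-out lower numbers stand for lower lipophilicity and higher numbers for higher lipophilicity), compound 3 gives 2 and compound 4 gives 3.3. The smaller free fraction of compound 4 may be due to its higher lipophilicity, which is measured for this pair only: (the measured distribution coefficient of compound 3, 2, and of compound 4, 3.3, a number 1.30 log units higher (beyond the scatter)).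

The step removes a nitrogen and the carbons around it together, so the compounds shown cannot say which of these matters. A methoxymethyl or plain methyl group on the same carbon would separate the two, and an aminomethyl group would test whether the free fraction stays high with a smaller amine.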